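Hydroxylated dienone series: solubility notes

A few compounds are considered here, and "the series" means these few. Any claim that something is new, unique, unknown or untested is made for them only; others in the source may bear on it.

Measured so far:
compound 1 `O=C(/C=C/c1cc(O)ccc1O)CC(=O)/C=C/c1cccc(O)c1O` — 100000 nM
compound 2 `O=C(/C=C/c1ccccc1O)CC(=O)/C=C/c1cc(O)ccc1O` — 4400 nM
compound 3 `O=C(/C=C/c1cccc(O)c1)/C=C/c1ccc(O)c(O)c1` — 60000 nM

In a physicochemical assay for solubility, using the shake flask method, with a stated time of 12 h (a higher number here means a more soluble compound, a lower number a less soluble compound), compound 1 gives 100000 nM, compound 2 gives 4400 nM and compound 3 gives 60000 nM. Within the data shown here, the one counted step is hydroxy in place of hydrogen on an aromatic carbon, which brought a 23-fold higher number from compound 2 to compound 1 (1.36 log units; beyond the scatter). The cores of compound 2 and compound 3 differ in more than one place; that difference is not broken down here.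

Compound 4 `O=C(/C=C/c1ccc(O)c(O)c1)/C=C/c1cc(O)ccc1O` is not yet measured. It arises from compound 3 by hydroxy in place of hydrogen on an aromatic carbon. This is the same kind of change as that from compound 2 to compound 1, though not the same: there the place was ortho to a hydroxy group and meta to a large group, here it is ortho to a large group and para to a hydroxy group. Resting on the step seen from compound 2 to compound 1 a 23-fold higher number from compound 2 to compound 1 (1.36 log units; beyond the scatter), a rise is expected, though a smaller one given the different surroundings; in this assay the expected step is a 2.5-fold higher number from compound 3 to compound 4 (0.40 log units; beyond the scatter). Compound 4 is estimated at 150000 nM, within 50000 nM to 600000 nM.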

Compound 4, solubility: 123000 nM
For compound 4 the middle estimate is 1.2-fold (0.09 log units) above the measured one; the measured number falls inside the stated range.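

Working notes: in this assay, hydroxy in place of hydrogen on an aromatic carbon raises the number on a second core, with a 2.1-fold higher number from compound 3 to compound 4 (0.31 log units; beyond the scatter) here against a 23-fold higher number from compound 2 to compound 1 (1.36 log units; beyond the scatter) on the earlier core, so the direction carries across these two pairs while the size does not. The new hydroxy also sits in a different place in each pair, ortho to a large group and para to a hydroxy group in the new step, so two pairs cannot separate the place from the core. No measurement at hand bears on why the two steps differ in size.

Open, as far as these compounds go, is how an amine or a carboxylic acid at that same place would behave in this assay on either core.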